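Aryl variation on the oxime ether series

The source may hold more compounds than are shown below. What is called first, only, known or untested is meant among the compounds shown, and "the series" means these compounds.

Compound 1 `CC(C)=CCC/C(C)=C/CC/C(C)=C/CC[C@@H]1[C@@]2(C)CC/C(=N\OCc3cn(-c4ccccc4)nn3)C(C)(C)[C@@H]2CC[C@@]1(C)O` carries a plain phenyl on the aromatic nitrogen of the five-membered ring with three nitrogens. Among the compounds with values here, in a functional assay on HeLa cells (Homo sapiens) for cytotoxicity, read by MTT assay, with a stated time of 48 h (a lower number here means a stronger inhibitor, a higher number a weaker inhibitor), compound 1 gives 7760 nM, the lowest of the three numbers measured so far. Compound 2 `CC(C)=CCC/C(C)=C/CC/C(C)=C/CC[C@@H]1[C@@]2(C)CC/C(=N\OCc3cn(-c4ccccc4C#N)nn3)C(C)(C)[C@@H]2CC[C@@]1(C)O` puts a cyano in place of hydrogen on an aromatic carbon of that phenyl; in this assay compound 2 gives 21200 nM, and the step is a 2.7-fold higher number from compound 1 to compound 2 (0.44 log units; beyond the scatter). Compound 3 `CC(C)=CCC/C(C)=C/CC/C(C)=C/CC[C@@H]1[C@@]2(C)CC/C(=N\OCc3cn(-c4cccc(O)c4)nn3)C(C)(C)[C@@H]2CC[C@@]1(C)O` puts a hydroxy in place of hydrogen on an aromatic carbon; in this assay compound 3 gives 13500 nM, with the step of a 1.7-fold higher number from compound 1 to compound 3 (0.24 log units; within the scatter). Between the two substituted rings the difference is a 1.6-fold lower number from compound 2 to compound 3 (0.20 log units; within the scatter).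

Compound 4 `CC(C)=CCC/C(C)=C/CC/C(C)=C/CC[C@@H]1[C@@]2(C)CC/C(=N\OCc3cn(-c4c(Cl)cc([N+](=O)[O-])cc4Cl)nn3)C(C)(C)[C@@H]2CC[C@@]1(C)O` is the next step from compound 1: 2,6-dichloro-4-nitrophenyl in place of phenyl on an aromatic nitrogen. Both measured steps from compound 1 bear on it, since each also alters the phenyl on the aromatic nitrogen: one gave a higher number beyond the scatter, the other a higher number within it. No substituted phenyl measured so far gives a lower number than compound 1. A higher number is therefore expected for compound 4 in this assay, of modest size, estimated as a 2.3-fold higher number from compound 1 to compound 4 (0.37 log units; beyond the scatter). The estimate for compound 4 in this assay is 18000 nM, with a range from 8000 nM to 42000 nM.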

Compound 4, half-maximal inhibitory concentration: 23000 nM
For compound 4 the middle estimate is 1.3-fold (0.11 log units) below the measured one; measured number inside the range.
By their numbers in this assay, from the lowest: compounds 1, 3, 2 and 4 (each within the scatter of the next, the first and the last beyond it).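

On the aromatic nitrogen, 2,6-dichloro-4-nitrophenyl brings 11 heavy atoms in place of the 6 of phenyl, plus 2 hydrogen-bond acceptors, yet the change in this assay remains modest (a 3.0-fold higher number from compound 1 to compound 4 (0.47 log units; beyond the scatter)). Compound 4 is not separated from either of the other substituted rings (a 1.7-fold higher number from compound 3 to compound 4 (0.23 log units; within the scatter); a 1.1-fold higher number from compound 2 to compound 4 (0.04 log units; within the scatter)), so the doubly chlorinated nitro ring, the 2-cyanophenyl and the 3-hydroxyphenyl cannot be told apart here, although compounds 2 and 4 lie beyond the scatter of compound 1 and compound 3 lies within it. No evidence on hand accounts for this step.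

The effects of the chlorines and the nitro group remain unseparated, and 2,6-dichlorophenyl and 4-nitrophenyl compared with compound 1 would divide the step between them. Also open, going by these compounds, is whether any group on this nitrogen can give a number clearly lower than that of compound 1, for example an aminophenyl, a carboxyphenyl or a longer alkyl chain in place of the aromatic ring.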